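The source may report more compounds than this note shows. Statements on the series, on what has been measured and on what is new or still open speak of the compounds shown alone.

Measured so far in a functional assay on HeLa cells (Homo sapiens) for antiproliferative activity, read by MTT assay, with a stated time of 48 h (a lower number here means a stronger inhibitor, a higher number a weaker inhibitor), lower numbers being stronger:

- compound 1 `COc1ccc(-c2cn3cc(C4=CCN(S(=O)(=O)CCc5ccccc5)CC4)ccc3n2)cc1OC` gives 8980 nM
- compound 2 `COc1ccc(-c2cn3cc(C4=CCN(C(=O)C(C)(C)C)CC4)ccc3n2)cc1OC` gives 5480 nM
- compound 3 `COc1ccc(-c2cn3cc(C4=CCN(C(=O)c5ccccc5)CC4)ccc3n2)cc1OC` gives 10200 nM

These three values cannot be told apart, and compound 1 sits among them with no clear rank. The measured steps are a 1.6-fold lower number from compound 1 to compound 2 (0.21 log units; within the scatter), a 1.1-fold higher number from compound 1 to compound 3 (0.06 log units; within the scatter) and a 1.9-fold higher number from compound 2 to compound 3 (0.27 log units; within the scatter). Each one lies within the normal scatter of repeated measurements.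

The next compound is compound 4 `COc1ccc(-c2cn3cc(C4=CCN(S(=O)(=O)C5CCCC5)CC4)ccc3n2)cc1OC`, which keeps the sulfonyl group of compound 1 and the shared core. The change is cyclopentyl in place of phenethyl on a sulfonyl sulfur. Going by the values given here, no measured step swaps one sulfonyl group for another, so the evidence is indirect. The nearest evidence is that even replacing the whole phenethylsulfonyl group made little measurable difference, as seen in a 1.6-fold lower number from compound 1 to compound 2 (0.21 log units; within the scatter) and a 1.1-fold higher number from compound 1 to compound 3 (0.06 log units; within the scatter). Neither step shows that this part of the molecule moves the number much, although three compounds are a thin basis for that.

The expected result is therefore no change beyond the scatter, namely a 1.1-fold lower number from compound 1 to compound 4 (0.05 log units; within the scatter).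

The estimated value for compound 4 is 8000 nM, with an expected range from 3800 nM to 16000 nM.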

Compound 4, half-maximal inhibitory concentration: 6470 nM
The estimate for compound 4 lay 1.2-fold (0.09 log units) above the measured number; low and high end bracket the measured number.
By their numbers in this assay, from the lowest: compounds 2, 4, 1 and 3 (each within the scatter of the next).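

Going by these compounds alone, this is the first step that swaps one sulfonyl group directly for another. In this assay, phenethyl, with its six-membered aromatic ring and 8 heavy atoms, gives way on the sulfonyl sulfur to cyclopentyl, with its five-membered non-aromatic ring and 5 heavy atoms, and the result is small (a 1.4-fold lower number from compound 1 to compound 4 (0.14 log units; within the scatter)), so in this pair neither the aromatic ring nor the larger atom count is tied to a measurable change. Cyclopentylsulfonyl also cannot be told apart from the two carbonyl groups on the same ring nitrogen (a 1.6-fold lower number from compound 3 to compound 4 (0.20 log units; within the scatter); a 1.2-fold higher number from compound 2 to compound 4 (0.07 log units; within the scatter)), which extends the flat picture to all four compounds, and no supporting measurement explains why the number stays so flat.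

Still open, on these data alone, is whether a chain ending in an amine or a carboxylic acid on the sulfonyl sulfur would leave the number just as unmoved. As far as these compounds go, all four compounds also share one core and carry a sulfonyl or carbonyl group on the ring nitrogen, so the effect of a bare ring nitrogen or of changes to the core remains unknown.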